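A Larger Side Chain on the Shared Core

A few compounds are considered here, and "the series" means these few. Any claim that something is new, unique, unknown or untested is made for them only; others in the source may bear on it.

Of the compounds shown here, three have so far been tested in a functional assay on K562 cells (Homo sapiens) for cytotoxicity, read by MTT assay, with a stated time of 72 h; a lower number here means a stronger inhibitor, a higher number a weaker inhibitor. Compound 1 `CC1=CCC[C@H]2[C@](C)(CC3=CC(=O)C=C(NCCC(=O)O)C3=O)[C@@H](C)CC[C@]12C` carries a large hydrocarbon frame on the shared core, and in this assay compound 1 gives 15500 nM, the lowest of the three numbers. Compound 2 `CC(C)(C)C1=CC(=O)C=C(NCC(=O)O)C1=O` instead carries a tert-butyl group and a short acid-bearing chain on the nitrogen; in this assay compound 2 gives 85000 nM, the highest of the three numbers, although the nearest neighbour sits within the usual scatter of it. That neighbour is compound 3 `CC(C)[C@@H](NC1=CC(=O)C=C(C(C)(C)C)C1=O)C(=O)O`, which differs from compound 2 only by an isopropyl in place of hydrogen on a saturated chain carbon bound to an amine nitrogen and a carbonyl carbon; in this assay compound 3 gives 57800 nM.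

Compound 4 `CC(C)C[C@H](NC1=CC(=O)C=C(C(C)(C)C)C1=O)C(=O)O` has not yet been measured. It differs from compound 2 as follows: isobutyl in place of hydrogen on a saturated chain carbon bound to an amine nitrogen and a carbonyl carbon. Among the measured compounds shown here, the one measured step that bears on this change is the step from compound 2 to compound 3, a 1.5-fold lower number from compound 2 to compound 3 (0.17 log units; within the scatter), where a branched group entered at the same place and the number moved only a little. Compound 4 is therefore expected to land close to compound 2, with an expected step of a 1.5-fold lower number from compound 2 to compound 4 (0.19 log units; within the scatter). In this assay compound 4 is estimated at 55000 nM, with a likely range from 27000 nM to 110000 nM.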

Compound 4, half-maximal inhibitory concentration: 76500 nM
For compound 4 the middle estimate is 1.4-fold (0.14 log units) below the measured one; low and high end bracket the measured number.
By their numbers in this assay, from the lowest: compound 1; then compounds 3, 4 and 2 (each within the scatter of the next).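

In this assay, placing isobutyl on the saturated chain carbon bound to an amine nitrogen and a carbonyl carbon gives a 1.1-fold lower number from compound 2 to compound 4 (0.05 log units; within the scatter). The earlier step, a 1.5-fold lower number from compound 2 to compound 3 (0.17 log units; within the scatter), rested on a single group, whereas two different groups at this carbon now leave the number within the scatter of compound 2, including one with 4 carbon atoms. Nothing available explains why these replacements leave the number so close to that of compound 2.

On these data alone, the groups compared at this carbon are hydrogen, isopropyl and isobutyl, so it remains open whether an amine, a hydroxyl group or a phenyl ring in the same place would move the number beyond the scatter. Also open, as far as these compounds go, is whether isobutyl would leave the number just as close on a compound carrying the large hydrocarbon frame of compound 1 instead of tert-butyl.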